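The compounds below may be only part of what the source reports. "The series", "measured", "known", "first", "only" and "open" are said of these compounds alone.

Compound 3 `COCC(C)(C)Nc1nc(C)nc2c1nnn2-c1ccc(C(C)C)cc1Br` gives 195 nM in an in vitro assay on 293-EBNA cells for binding affinity to corticotropin-releasing factor receptor 1 (Homo sapiens); on this read-out higher numbers stand for weaker inhibition and lower numbers for stronger inhibition; among the three numbers it sits at the upper end, within the scatter of compound 1 `Cc1nc(N2CCCC2)c2nnn(-c3ccc(C(C)C)cc3Br)c2n1` at 194 nM and well apart from compound 2 `COCC(COC)N(C)c1nc(C)nc2c1nnn2-c1ccc(C(C)C)cc1Br` at 21.3 nM. Compound 4 `CCC(Nc1nc(C)nc2c1nnn2-c1ccc(C(C)C)cc1Br)C(=O)OC` differs from compound 3 by 1-(methoxycarbonyl)propyl in place of 1-(methoxymethyl)-1-methylethyl on a nitrogen on an aromatic ring. Two measured steps alter the substituent at this same nitrogen: a 1.0-fold higher number from compound 1 to compound 3 (0.00 log units; within the scatter) and a 9.2-fold higher number from compound 2 to compound 3 (0.96 log units; beyond the scatter). Changes at this position therefore span from no effect to a modest shift, and the ester-bearing group of compound 4 has no measured counterpart, so the direction is open. The step from compound 3 to compound 4 is expected to be roughly a 1.3-fold lower number from compound 3 to compound 4 (0.11 log units; within the scatter). For compound 4 the estimate in this assay is 150 nM, with a range of 40 nM to 600 nM.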

Compound 4, inhibition constant: 19.4 nM
For compound 4 the middle estimate is 7.7-fold (0.89 log units) above the measured one, outside the stated range (below it).
By their numbers in this assay, from the lowest: compounds 4 and 2 (each within the scatter of the next); then compounds 1 and 3 (each within the scatter of the next).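

In this assay, 1-(methoxycarbonyl)propyl in place of 1-(methoxymethyl)-1-methylethyl on the same nitrogen gives a 10-fold lower number from compound 3 to compound 4 (1.00 log units; beyond the scatter), so this position responds strongly even when the nitrogen keeps its hydrogen. Against the pyrrolidin-1-yl group the step is similar, a 10-fold lower number from compound 1 to compound 4 (1.00 log units; beyond the scatter), while a 1.1-fold lower number from compound 2 to compound 4 (0.04 log units; within the scatter) places the open-chain ester level with compound 2, which no longer stands alone at the low end. Nothing available explains this shift. Open, from the compounds shown here alone, is which part of the new group carries the step: whether a carboxylic acid in place of the methyl ester, or a longer chain in place of its ethyl, would hold the number.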